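A few compounds are considered here, and "the series" means these few. Any claim that something is new, unique, unknown or untested is made for them only; others in the source may bear on it.

In a functional assay on MDA-MB-231 cells (Homo sapiens) for inhibition, read by WST assay, with a stated time of 48 h (a lower number here means a stronger inhibitor of growth, a higher number a weaker inhibitor of growth), compound 1 `CC/C=C\C/C=C\C/C=C\C/C=C\C/C=C\C/C=C\CCC(=O)Oc1ccc(C(C)C)cc1C(C)C` gives 12600 nM and compound 2 `CC/C=C\C/C=C\C/C=C\C/C=C\C/C=C\C/C=C\CCC(=O)Nc1ccccc1C(C)C` gives 8500 nM, so these two values lie within the usual scatter of each other. Compound 3 `CC/C=C\C/C=C\C/C=C\C/C=C\C/C=C\C/C=C\CCC(=O)Oc1ccccc1` differs from compound 1 in one place, on an oxygen next to a carbonyl group: phenyl in place of 2,4-diisopropylphenyl on an oxygen next to a carbonyl group. Among the measured compounds shown here, no measured pair shows this change on its own, so the size of the step is uncertain. In this assay, the expected step of a 1.2-fold higher number from compound 1 to compound 3 (0.08 log units; within the scatter) is small, towards weaker inhibition of growth, and not beyond the scatter. For compound 3, the estimated value is 15000 nM, with an expected range from 7000 nM to 35000 nM.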

Compound 3, concentration for total growth inhibition: > 25000 nM
Compound 3 gave a limit, no number; the forecaster's own chance of this, stated with the estimate: 15%; at least 1.6-fold (0.22 log units) between middle value and limit.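

In this assay compound 3 gives > 25000 nM, which is a limit of the assay and not a number. Phenyl in place of 2,4-diisopropylphenyl on an oxygen next to a carbonyl group gives an at least 1.9-fold higher number from compound 1 to compound 3 (0.29 log units; that floor lies within the scatter), so this change alone is not firmly shown to weaken growth inhibition. Phenoxy in place of (2-isopropylphenyl)amino on a carbonyl carbon gives an at least 2.9-fold higher number from compound 2 to compound 3 (0.46 log units; beyond the scatter), the first step in this set that clears the scatter, towards weaker inhibition.

From the compounds shown here alone, the true size of both steps stays open. So does the effect of an amine or a carboxylic acid on that phenyl.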